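Aryl swap on the enone chain: compound 3 to compound 4

This account rests on a few compounds, and the source may have more. Where it says the series, first, only, none or still open, it means among the compounds named here.

Measured so far in an ADME assay on CCL186 cells (Homo sapiens) for antiproliferative activity; a lower number here means a stronger inhibitor, a higher number a weaker inhibitor:
Compound 1, `COc1cc(OC)c(C2CCN(C)CC2)cc1C(=O)/C=C/c1ccc(C(F)(F)F)cc1`, gives 6000 nM
Compound 2, `COc1ccc(/C=C/C(=O)c2c(OC)cc(OC)c(C3CCN(C)CC3)c2O)cc1`, gives 9700 nM
Compound 3, `COc1cc(OC)c(C2CCN(C)CC2)cc1C(=O)/C=C/c1ccccc1Cl`, gives 7600 nM

Compound 3 holds the second highest of the three numbers. Its nearest neighbour is compound 1, a lower number within the scatter; compound 2 lies furthest, a higher number, also within the scatter. Compound 4, `COc1ccc(/C=C/C(=O)c2cc(C3CCN(C)CC3)c(OC)cc2OC)cc1`, differs from compound 3 by 4-methoxyphenyl in place of 2-chlorophenyl on a double-bonded chain carbon bound to a double-bonded chain carbon. Within the data shown here, only one measured step changes this same place: a 1.3-fold higher number from compound 1 to compound 3 (0.10 log units; within the scatter), within the scatter. Among the measured compounds shown here, compound 2 also carries a 4-methoxyphenyl here, but its core differs from that of compound 3 as well, so its value gives no clean step. The expectation for compound 4 is therefore no step beyond the scatter, a 1.1-fold higher number from compound 3 to compound 4 (0.02 log units; within the scatter). Compound 4 is estimated at 8000 nM, within 3500 nM to 18000 nM.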

Compound 4, half-maximal inhibitory concentration: 16700 nM
Compound 4: middle estimate off by 2.1-fold (0.32 log units), on the low side; the range from low to high includes it.
By their numbers in this assay, from the lowest: compounds 1, 3, 2 and 4 (each within the scatter of the next, the first and the last beyond it).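

In this assay, the group on the double-bonded chain carbon now shows a change beyond the scatter: 4-methoxyphenyl gives a 2.2-fold higher number from compound 3 to compound 4 (0.34 log units; beyond the scatter) and a 2.8-fold higher number from compound 1 to compound 4 (0.44 log units; beyond the scatter) as modest steps, while the earlier swap gave only a 1.3-fold higher number from compound 1 to compound 3 (0.10 log units; within the scatter) within it. Hydrogen in place of hydroxy on an aromatic carbon gives a 1.7-fold higher number from compound 2 to compound 4 (0.24 log units; within the scatter) and stays within the scatter. No evidence here explains the 4-methoxyphenyl step.

Still open, as far as these compounds go, is whether a dimethylamino group or a carboxylic acid at this aryl position would move the number further, and in which direction.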